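Desmethyl pyrrolidinone analogue of compound 1: lipophilicity outlook

A few compounds are considered here, and "the series" means these few. Any claim that something is new, unique, unknown or untested is made for them only; others in the source may bear on it.

compound 1 `C[C@@H]1CC(=O)N(c2cnc(NCc3c(F)ccc4c3CCO4)n3cnnc23)C1` — 1.8
compound 2 `CN(C)C(=O)c1cc(-c2cnc(NCc3c(F)ccc4c3CCO4)c3cn[nH]c(=O)c23)n(C)n1` — 2.1
compound 3 `Cc1nc(CN(C)C)ccc1-c1cnc(NCc2c(F)ccc3c2CCO3)c2cn[nH]c(=O)c12` — 2

In a physicochemical assay for lipophilicity, using the shake flask method, in phosphate buffer, measured as octanol-water partition, with a stated time of 30 min, at pH 7.4 (on this read-out higher numbers stand for higher lipophilicity and lower numbers for lower lipophilicity), compound 1 gives 1.8, the lowest of the three numbers, yet compound 3 at 2 and compound 2 at 2.1 both lie within the scatter of it, so no order among the three can be read from these data.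

Within the data shown here, the only step measured so far is a number 0.10 log units lower from compound 2 to compound 3 (within the scatter), a swap of one aromatic substituent for another on the shared core. It leaves the pyrrolidinone untouched and does not bear on the change now under consideration.

Compound 4 `O=C1CCCN1c1cnc(NCc2c(F)ccc3c2CCO3)n2cnnc12` differs from compound 1 in one place: hydrogen in place of methyl on a saturated ring carbon. No measured pair in this set reports the effect of removing a methyl from a saturated ring carbon, so the expectation rests on the change alone rather than on any shown step.

Compound 4 is expected to come in slightly lower than compound 1, by a number 0.40 log units lower from compound 1 to compound 4 (beyond the scatter), a shift that may well stay inside the scatter of this assay. The estimate for compound 4 is 1.4, with a range from 1 to 1.8.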

Compound 4, distribution coefficient: 1.3
For compound 4 the middle estimate is 0.10 log units above the measured one, and the stated range covers the measured number.
By their numbers in this assay, from the lowest: compound 4; then compounds 1, 3 and 2 (each within the scatter of the next).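

Working notes on the 4-methyl-2-oxopyrrolidin-1-yl to 2-oxopyrrolidin-1-yl change: in this assay, hydrogen in place of methyl on the saturated ring carbon gives a number 0.50 log units lower from compound 1 to compound 4 (beyond the scatter). Among these compounds, this is the first step to lie beyond the scatter, and the first to touch the five-membered non-aromatic ring rather than an aromatic substituent, so this ring carbon, two ring bonds from the ring nitrogen, is a place where a change of a single heavy atom moves the read-out measurably on the core of compound 1. Nothing available on the series explains the size or direction of this step.

Only methyl and hydrogen are shown at this ring carbon, so the response to a longer chain such as ethyl, to a hydroxyl or to an amine at the same place remains open. The change also rests on a single pair, which leaves open whether the same removal of methyl would give a step of similar size on a different core.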